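A Methyl on the Saturated Ring: Expecting Little Change

A few compounds are considered here, and "the series" means these few. Any claim that something is new, unique, unknown or untested is made for them only; others in the source may bear on it.

Measured so far:
compound 1, `COc1cc2c(Oc3ccc(NC(=O)c4cc(-c5ccccc5)nc5ccccc45)cc3F)ccnc2cc1OCCCN1CCCCC1`, 110 nM
compound 2, `COc1ccc(-c2cc(C(=O)Nc3ccc(Oc4ccnc5cc(OCCCN6CCCCC6)c(OC)cc45)c(F)c3)c3ccccc3n2)cc1`, 290 nM
compound 3, `COc1cc2c(Oc3ccc(NC(=O)c4cc(-c5cccc(Cl)c5)nc5ccccc45)cc3F)ccnc2cc1OCCCN1CCCCC1`, 11 nM

All three were tested in a functional assay on NCI-H460 cells (Homo sapiens) for cytotoxicity, read by MTT assay, with a stated time of 72 h; a higher number here means a weaker inhibitor, a lower number a stronger inhibitor. Compound 1 sits second highest of the three numbers: compound 2 lies above it by a 2.6-fold higher number from compound 1 to compound 2 (0.42 log units; beyond the scatter), and compound 3 lies below it by a 10-fold lower number from compound 1 to compound 3 (1.00 log units; beyond the scatter). The gap between the other two, a 26-fold lower number from compound 2 to compound 3 (1.42 log units; beyond the scatter), is the widest in the set. Every one of these steps changes the aromatic group attached to the shared core of compound 1.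

Compound 4, `COc1cc2c(Oc3ccc(NC(=O)c4cc(-c5ccccc5)nc5ccccc45)cc3F)ccnc2cc1OCCCN1CCC(C)CC1`, departs from compound 1 elsewhere: methyl in place of hydrogen on a saturated ring carbon. Within the data shown here, the saturated ring carrying this methyl is untouched in compounds 2 and 3, so none of the measured steps speaks to this change. There is no evidence in this set that a small addition on that ring shifts the number either way, and the expectation is therefore a step within the usual scatter rather than a clear move in one direction.

On that basis compound 4 is expected to give about 110 nM in this assay, with a plausible range from 40 nM to 300 nM, which would amount to a step of no change at the digits printed from compound 1 to compound 4 (within the scatter).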

Compound 4, half-maximal inhibitory concentration: 68 nM
Beside the measured number, compound 4's estimate is 1.6-fold (0.21 log units) above it; measured number inside the range.
By their numbers in this assay, from the lowest: compound 3; then compounds 4 and 1 (each within the scatter of the next); then compound 2.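

Among these compounds, until now every step changed the aromatic group, so compound 4 gives the first reading at the saturated ring, on a carbon three ring bonds from the ring nitrogen, and in this assay the move from piperidin-1-yl to 4-methylpiperidin-1-yl is a 1.6-fold lower number from compound 1 to compound 4 (0.21 log units; within the scatter). One added methyl at this carbon therefore leaves compound 4 and compound 1 indistinguishable, whereas a chloro on the aromatic group gives a clear step, a 10-fold lower number from compound 1 to compound 3 (1.00 log units; beyond the scatter). Nothing measured here explains the outcome at the saturated ring.

On these data alone, a single small methyl says little about the wider tolerance of this carbon, so it remains open whether a longer chain such as propyl, a hydroxyl or a carboxylic acid at the same place would also leave the number within the scatter. As far as these compounds go, it also remains open whether the 4-methylpiperidin-1-yl group would behave the same way when paired with the 3-chlorophenyl group of compound 3.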